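The source may hold more compounds than are shown below. What is called first, only, known or untested is meant among the compounds shown, and "the series" means these compounds.

Working notes on a small set of benzylamine-linked oxadiazoles in an assay on isolated protein for inhibition of histone deacetylase 8 (Homo sapiens), read by fluorescence, with a stated time of 20 min; a higher number here means a weaker inhibitor, a lower number a stronger inhibitor.

Compound 1 `Nc1ccccc1NC(=O)c1ccc(CNCc2nc(-c3ccc(F)cc3)no2)cc1` carries a 2-aminophenyl amide. In this assay compound 1 gives > 10000 nM, which is a limit of the assay and not a number. Compound 2 `Nc1ccccc1NC(=O)c1ccc(CNCc2nc(-c3cccs3)no2)cc1` differs from compound 1 by thiophen-2-yl in place of 4-fluorophenyl on an aromatic carbon. In this assay compound 2 gives > 10000 nM, again a limit rather than a number. The step that the two limits leave unreadable from compound 1 to compound 2 therefore cannot be read, because the limit of > 10000 nM in this assay, at which 2 of the 3 values shown sit, holds both values.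

Compound 3 `O=C(NO)c1ccc(CNCc2nc(-c3ccc(F)cc3)no2)cc1` keeps the core of compound 1 but differs by hydroxy in place of 2-aminophenyl on an amide-type nitrogen. In this assay, among the compounds with values here, compound 3 gives 230 nM, the only number in the set, and the step of an at least 43-fold lower number from compound 1 to compound 3 (1.63 log units; beyond the scatter) is large.

Compound 4 `O=C(NO)c1ccc(CNCc2nc(-c3cccs3)no2)cc1` is not yet measured; it differs from compound 3 by thiophen-2-yl in place of 4-fluorophenyl on an aromatic carbon, the same change as from compound 1 to compound 2, which gave no readable step. For compound 4 the expected step of a 1.1-fold higher number from compound 3 to compound 4 (0.04 log units; within the scatter) is near zero, resting only on compound 3 at 230 nM. Compound 4 is estimated at 250 nM, within 80 nM to 800 nM.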

Compound 4, half-maximal inhibitory concentration: 8260 nM
For compound 4 the middle estimate is 33-fold (1.52 log units) below the measured one; the measured number lies above the stated range.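

In this assay, hydroxy in place of 2-aminophenyl gives an at least 1.2-fold lower number from compound 2 to compound 4 (0.08 log units; that floor lies within the scatter), and thiophen-2-yl in place of 4-fluorophenyl gives a 36-fold higher number from compound 3 to compound 4 (1.56 log units; beyond the scatter). The hydroxy change can thus be set side by side on two cores: the same change on two cores in this assay, an at least 43-fold lower number (1.63 log units; beyond the scatter) from compound 1 to compound 3 and an at least 1.2-fold lower number (0.08 log units; that floor lies within the scatter) from compound 2 to compound 4; the limit leaves it open whether they differ. This shows a lower number beyond the scatter for the 4-fluorophenyl pair, but it does not show that a step of that size carries over to the thiophen-2-yl pair, and the thiophen-2-yl step between the 2-aminophenyl amides cannot be read.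

Open, from the compounds shown here alone, is whether furan-2-yl or unsubstituted phenyl in that place would give a number nearer that of compound 3 or that of compound 4. The 2-aminophenyl amides offer no number for comparison: the limit of > 10000 nM in this assay, at which 2 of the 4 values shown sit.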